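This account rests on a few compounds, and the source may have more. Where it says the series, first, only, none or still open, it means among the compounds named here.

Measured so far in an assay on isolated protein for inhibition of serine/threonine-protein kinase TNNI3K (Homo sapiens); on this read-out higher numbers stand for weaker inhibition and lower numbers for stronger inhibition:
compound 1 `CNc1cc(Oc2ccc(NC(=O)Nc3cccc(C(F)(F)F)c3)cc2)ncn1`: 40 nM
compound 2 `CNc1cc(Oc2ccc(NC(=O)Nc3cccc(C(C)(F)F)c3)cc2)ncn1`: 40 nM
compound 3 `CNc1cc(Oc2ccc(NC(=O)Nc3cccc(CF)c3)cc2)ncn1`: 400 nM

Compound 1 stands level with compound 2, no change at the digits printed from compound 1 to compound 2 (within the scatter); together they give the lowest numbers of the three. Compound 3 lies furthest off, a 10-fold higher number from compound 1 to compound 3 (1.00 log units; beyond the scatter), and a 10-fold higher number from compound 2 to compound 3 (1.00 log units; beyond the scatter) is of the same size. All three steps concern the trifluoromethyl, 1,1-difluoroethyl and fluoromethyl groups; none touches the nitrogen on the aromatic ring at the other end of the shared core.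

Compound 4 `CC(C)Nc1cc(Oc2ccc(NC(=O)Nc3cccc(C(F)(F)F)c3)cc2)ncn1` differs from compound 1 exactly there: isopropyl in place of methyl on a nitrogen on an aromatic ring. Among the compounds with values here, no measured step bears on this position, so the series gives no scale for it. In this assay compound 4 is therefore expected to stay near compound 1, no change at the digits printed from compound 1 to compound 4 (within the scatter), with no step beyond the scatter. The estimate for compound 4 is 40 nM, ranging from 15 nM to 120 nM.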

Compound 4, half-maximal inhibitory concentration: 40 nM
Estimate against measurement, compound 4: no gap at the digits printed; measured number inside the range.
By their numbers in this assay, from the lowest: compounds 1, 2 and 4 (each within the scatter of the next); then compound 3.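

In this assay, isopropyl in place of methyl on a nitrogen on an aromatic ring gives no change at the digits printed from compound 1 to compound 4 (within the scatter) with the trifluoromethyl group held constant. This gives the position its first scale: going from 1 heavy atom to 3 heavy atoms in this group leaves the number within the scatter. Nothing available accounts for this result.

Still open, from the compounds shown here alone, is how this nitrogen behaves with a hydrogen in place of the alkyl group, a cyclopropyl ring, a tert-butyl group or a longer chain. Also open, going by these compounds, is whether isopropyl gives the same outcome alongside the fluoromethyl group of compound 3.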